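From fluoro to hydroxy in a growth inhibition series

A few compounds are considered here, and "the series" means these few. Any claim that something is new, unique, unknown or untested is made for them only; others in the source may bear on it.

- compound 1 `Cn1c(=O)c(S(=O)(=O)c2ccc(OC(=O)CCCCC3SCC4NC(=O)NC43)cc2)cc2cnc(Nc3ccc4[nH]ccc4c3)nc21` gives 100 nM as measured
- compound 2 `Cn1c(=O)c(S(=O)(=O)c2ccc(F)cc2)cc2cnc(Nc3ccc4[nH]ccc4c3)nc21` gives 75 nM as measured

Both numbers come from a functional assay on MIA PaCa-2 cells (Homo sapiens) for inhibition, read by trypan blue exclusion, with a stated time of 72 h (on this read-out lower numbers stand for stronger inhibition of growth and higher numbers for weaker inhibition of growth), and lie within the usual scatter of each other, so compound 2 stands level with compound 1 and the two cannot be ranked. Compound 3 `Cn1c(=O)c(S(=O)(=O)c2ccc(O)cc2)cc2cnc(Nc3ccc4[nH]ccc4c3)nc21` has not yet been measured. It differs from compound 2 in one place hydroxy in place of fluoro on an aromatic carbon and carries hydroxy in place of fluoro on an aromatic carbon, para to a large group. Among the measured compounds shown here, no step between measured compounds shows what such a change does. In this assay the expected change is a 1.3-fold higher number from compound 2 to compound 3 (0.12 log units; within the scatter) and is not expected to go beyond the scatter in either direction. Compound 3 is estimated at 100 nM in this test, with an expected range from 30 nM to 300 nM once it is measured.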

Compound 3, concentration for 50% growth inhibition: 100 nM
Compound 3: middle estimate and measured number agree at the digits printed, within the range that was stated.
By their numbers in this assay, from the lowest: compounds 2, 1 and 3 (each within the scatter of the next).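

In this assay, the step from fluoro to hydroxy on the aromatic carbon, para to a large group, reads a 1.3-fold higher number from compound 2 to compound 3 (0.12 log units; within the scatter). Among the compounds shown here, this is the first single-place step, and it shows that compound 3, with a hydroxy carrying one hydrogen-bond donor and one acceptor, stands level with compound 2, whose fluoro has neither, so this exchange leaves growth inhibition within the scatter. Nothing available here explains why the two compounds stand level.

The compounds shown leave open whether a larger or differently charged group at this position, such as an amine, a carboxylic acid or a longer chain, would also stay level. They also leave open whether a hydroxy would be tolerated equally at another carbon of the same ring.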